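Adding a Second Phenyl to an Imidazole Inhibitor

This account rests on a few compounds, and the source may have more. Where it says the series, first, only, none or still open, it means among the compounds named here.

Three small imidazole compounds have been tested in an in vitro assay on V79MZ cells for inhibition of cytochrome P450 11B1, mitochondrial (Homo sapiens); a higher number here means a weaker inhibitor, a lower number a stronger inhibitor. Compound 1 `c1ccc(-c2cccc(Cn3ccnc3)c2)cc1` gives 46 nM in this assay. Compound 2 `Cc1ccccc1Cn1ccnc1` gives 61 nM, and compound 3 `c1ccc(-c2ccc(Cn3ccnc3)cc2)cc1` gives 32 nM. Compound 1 thus sits among the others with its nearest neighbour being compound 2 and its furthest being compound 3, and both gaps are within the usual scatter of repeated measurements, so none of the three can be called stronger or weaker than another on these numbers.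

Compound 4 `c1ccc(-c2cc(Cn3ccnc3)cc(-c3ccccc3)c2)cc1` has not yet been measured. It differs from compound 1 in one place: phenyl in place of hydrogen on an aromatic carbon. Among the measured compounds shown here, no pair of measured compounds that differ in one place is available to show what such a change does, so the expectation rests on the three numbers alone, which all lie close together.

The step expected from compound 1 to compound 4 in this assay is a 1.1-fold higher number from compound 1 to compound 4 (0.04 log units; within the scatter), that is, none beyond the scatter. Compound 4 is therefore estimated at 50 nM, with a likely range from 15 nM to 170 nM.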

Compound 4, half-maximal inhibitory concentration: 128 nM
Beside the measured number, compound 4's estimate is 2.6-fold (0.41 log units) below it; the measured number falls inside the stated range.
By their numbers in this assay, from the lowest: compounds 3, 1 and 2 (each within the scatter of the next); then compound 4.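

Among the compounds shown here, the earlier compounds held no pair differing in one place, so this is the first direct reading of a single change: in this assay, phenyl in place of hydrogen on an aromatic carbon gives a 2.8-fold higher number from compound 1 to compound 4 (0.44 log units; beyond the scatter) and so a modest loss of inhibition. At this place, meta to the (1H-imidazol-1-yl)methyl group and meta to the phenyl group already present, a second phenyl leaves a working inhibitor but adds no strength. Nothing measured here explains the rise in the number.

On these data alone, it stays open whether this loss belongs to phenyl in particular or would come with any group at this carbon. A methoxy group, an amine or a carboxylic acid at the same place would show whether the number stays near that of compound 1 or rises as well.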